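The source may report more compounds than this note shows. Statements on the series, on what has been measured and on what is new or still open speak of the compounds shown alone.

For the measured compounds named here, in a physicochemical assay for lipophilicity, using the shake flask method, at pH 7.4 (on this read-out higher numbers stand for higher lipophilicity and lower numbers for lower lipophilicity), compound 1 (`CCCC(Oc1ccc(-n2cc(C#N)cn2)cc1)c1ccc(C(=O)NCCC(=O)O)cc1`) gives 1.2, the lower of the two numbers so far. Compound 2 (`CC(C)(C)C(Oc1ccc(-n2cc(C(F)(F)F)cn2)cc1)c1ccc(C(=O)NCCC(=O)O)cc1`) gives 3.7, and that gap lies well beyond the usual scatter of repeated measurements.

Compound 3 (`CCCC(Oc1ccc(-n2cc(Cl)cn2)cc1)c1ccc(C(=O)NCCC(=O)O)cc1`) keeps the core of compound 1 and differs from it in one place: chloro in place of cyano on an aromatic carbon. Put another way, the 4-cyano-1H-pyrazol-1-yl group of compound 1 becomes the 4-chloro-1H-pyrazol-1-yl group of compound 3.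

Comparing two compounds that differ in a single place is the cleanest way to read the effect of a change, but no measured pair here offers such a comparison. Compound 2, at 3.7, differs from compound 1 in more than one place, so it cannot size this step. The expectation therefore rests on the structural change alone and points upward, beyond the scatter: the expected change is a number 0.90 log units higher from compound 1 to compound 3 (beyond the scatter). For compound 3 the estimated value is 2.1, with an expected range from 1.6 to 2.7.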

Compound 3, distribution coefficient: 2.6
Estimate against measurement, compound 3: 0.50 log units below; measured number inside the range.
By their numbers in this assay, from the lowest: compound 1; then compound 3; then compound 2.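

In this assay, for the compounds shown here, the change from the 4-cyano-1H-pyrazol-1-yl group to the 4-chloro-1H-pyrazol-1-yl group gives the first comparison in which only one place differs: a number 1.40 log units higher from compound 1 to compound 3 (beyond the scatter) is a large step. It shows that the read-out responds strongly to the group on this aromatic carbon of the five-membered aromatic ring with 2 nitrogen, even when the rest of compound 1 stays unchanged in compound 3. The counted differences are plain: cyano leaves with 2 heavy atoms and 1 hydrogen-bond acceptor, chloro enters with 1 heavy atom and no hydrogen-bond acceptor, but no measurement on hand links either count to the step.

Compound 2 carries a trifluoromethyl group on the same kind of ring, but it differs from both compound 1 and compound 3 in more than one place, so its number cannot size the effect of that group alone. Going by these compounds alone, how a methyl group, a methoxy group or an amine on this same carbon would compare with chloro and cyano remains open, as does whether this step would keep its size with a different chain in place of the one shared by compound 1 and compound 3.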